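A few compounds are considered here, and "the series" means these few. Any claim that something is new, unique, unknown or untested is made for them only; others in the source may bear on it.

Measured so far:
- compound 1, `NS(=O)(=O)c1ccc(/C=C/c2ccc(O)c(O)c2)cc1`: 22300 nM
- compound 2, `COc1cccc(/C=C/c2ccc(S(N)(=O)=O)cc2)c1`: 11000 nM

In a functional assay on A549 cells (Homo sapiens) for inhibition (a lower number here means a stronger inhibitor of growth, a higher number a weaker inhibitor of growth), compound 1 gives 22300 nM. Compound 2 gives 11000 nM, a lower number, so compound 1 stands with the highest number of the two, and the gap to compound 2 lies beyond the scatter. Compound 3, `NS(=O)(=O)c1ccc(/C=C/c2ccc(O)cc2)cc1`, has not yet been measured in this assay. It differs from compound 1 in one place: hydrogen in place of hydroxy on an aromatic carbon. For the measured compounds named here, no measured pair shows this exact change, so its effect is uncertain. Compound 2, which carries one methoxy group rather than two hydroxy groups, gives 11000 nM, a lower number than compound 1, which hints that a single such group is tolerated. The step of a 1.5-fold lower number from compound 1 to compound 3 (0.17 log units; within the scatter) is expected to be small, toward a lower number, likely within the scatter. Compound 3 is estimated at 15000 nM, with a range from 5000 nM to 45000 nM.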

Compound 3, concentration for 50% growth inhibition: 13900 nM
Compound 3: middle estimate off by 1.1-fold (0.03 log units), on the high side; low and high end bracket the measured number.
By their numbers in this assay, from the lowest: compounds 2, 3 and 1 (each within the scatter of the next, the first and the last beyond it).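

In this assay, putting hydrogen in place of the hydroxy group that stands ortho to a hydroxy group gives a 1.6-fold lower number from compound 1 to compound 3 (0.21 log units; within the scatter), so this position can lose its hydroxy group without a change that stands clear of the scatter. For the compounds shown here, this is the first direct reading of the change, since compound 2 differs from compound 1 in more than one place. No measurement here explains this result.

From the compounds shown here alone, it remains open whether the hydroxy group still present in compound 3 matters for growth inhibition, and whether a fluorine atom or an amine at the vacated position would read differently from hydrogen. A single step also cannot tell whether the same change would behave alike in compounds with other groups elsewhere.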